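The compounds below may be only part of what the source reports. "The series", "measured", "known", "first", "only" and "open" are said of these compounds alone.

Three compounds have been measured in an ADME assay on MT4 cells (Homo sapiens) for cytotoxicity, read by spectrophotometry, with a stated time of 5 days; a lower number here means that less compound is tolerated, a higher number that more compound is tolerated:
Compound 1 `Cc1ccc2c(c1)/C(=N/NC(=S)NO)C(=O)N2CN1CCN(c2ccccc2)CC1` gives 420000 nM.
Compound 2 `CCn1cc(C(=O)O)c(=O)c2cc(F)c(N3CCN(CN4C(=O)/C(=N\NC(=S)NOC)c5cc(Cl)ccc54)CC3)cc21` gives 193000 nM.
Compound 3 `O=C1/C(=N\NC(=S)NO)c2cc(Cl)ccc2N1CN1CCN(c2ccccc2)CC1` gives 273000 nM.

Compound 3 and compound 1 share one core and differ by a single change, (methyl in place of chloro on an aromatic carbon), which gave a 1.5-fold higher number from compound 3 to compound 1 (0.19 log units; within the scatter). Compound 2 is built on a different core; the difference between the two cores is not broken down here. Compound 4 `CCn1cc(C(=O)O)c(=O)c2cc(F)c(N3CCN(CN4C(=O)/C(=N\NC(=S)NOC)c5cc(C)ccc54)CC3)cc21` has not yet been measured. It differs from compound 2 by methyl in place of chloro on an aromatic carbon, the same change at the same place as before. The expectation rests on compound 3 and compound 1, because their step of a 1.5-fold higher number from compound 3 to compound 1 (0.19 log units; within the scatter) lay within the scatter. Compound 4 is therefore expected to show a 1.5-fold higher number from compound 2 to compound 4 (0.18 log units; within the scatter) in this assay. Compound 4 is estimated at 290000 nM, with a likely range from 130000 nM to 600000 nM.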

Compound 4, half-maximal cytotoxic concentration: 238000 nM
Beside the measured number, compound 4's estimate is 1.2-fold (0.09 log units) above it, within the range that was stated.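

In this assay, methyl in place of chloro gave a 1.2-fold higher number from compound 2 to compound 4 (0.09 log units; within the scatter). Set beside the earlier step, the same change looks alike on the two cores: the same change on two cores in this assay, a 1.5-fold higher number (0.19 log units; within the scatter) from compound 3 to compound 1 and a 1.2-fold higher number (0.09 log units; within the scatter) from compound 2 to compound 4, 1.2-fold (0.10 log units) apart, within the scatter of two such steps. This shows that the swap carried across these two cores with no gap beyond the scatter, but each step is itself within the scatter, and the data show neither a real effect of the change on either core nor how it would behave on a third core.

The compounds shown carry only chloro or methyl at this place on the aromatic ring. On these data alone, what an amine or a longer chain such as propyl would give there remains open.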